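A Second Methoxy Group: Expected Effect on Growth Inhibition

The source may hold more compounds than are shown below. What is called first, only, known or untested is meant among the compounds shown, and "the series" means these compounds.

Compound 1, `CCCOC(=O)N1N=C(c2ccccc2)CC1c1cc(OC)c(OC)c(OC)c1`: in a functional assay on HeLa cells (Homo sapiens) for antiproliferative activity, read by MTT assay, with a stated time of 48 h (a higher number here means a weaker inhibitor of growth, a lower number a stronger inhibitor of growth), compound 1 gives > 10000 nM, which is a limit of the assay.
Compound 2, `CCCOC(=O)N1N=C(c2ccc(OC)cc2)CC1c1cc(OC)c(OC)c(OC)c1`: in this assay compound 2 gives > 10000 nM, also a limit of the assay.
Compound 3, `COC(=O)N1N=C(c2ccccc2)CC1c1ccc(OC)cc1`: in this assay compound 3 gives 12700 nM.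

Compound 4, `COC(=O)N1N=C(c2ccccc2)CC1c1ccc(OC)c(OC)c1`, is not yet measured. From compound 3 to compound 4 the change is methoxy in place of hydrogen on an aromatic carbon. The same kind of change, (methoxy in place of hydrogen on an aromatic carbon), was made from compound 1 to compound 2, but there the new group sits para to a large group, whereas in compound 4 it sits ortho to a methoxy group and meta to a large group. Its measured size is a step that the two limits leave unreadable from compound 1 to compound 2 because of the limit of > 10000 nM in this assay, at which 2 of the 3 values shown sit. The difference between the two cores is not broken down here. Without a readable precedent, only a small step is expected, a 1.1-fold lower number from compound 3 to compound 4 (0.02 log units; within the scatter), resting on compound 3 at 12700 nM. Compound 4 is therefore estimated at 12000 nM, with a fair chance that only a limit is reported.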

Compound 4, concentration for 50% growth inhibition: 5480 nM
Compound 4: the middle estimate sits 2.2-fold (0.34 log units) above what was measured, and the stated range covers the measured number.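

In this assay, the added methoxy group gives a 2.3-fold lower number from compound 3 to compound 4 (0.37 log units; beyond the scatter), so on the core of compound 3 this change brings a modest gain in growth inhibition. The same change on the core of compound 1 cannot be read, because both values there are limits: the limit of > 10000 nM in this assay, at which 2 of the 4 values shown sit. So the gain is seen on one core only, and nothing here shows whether it carries over to the other core or explains why the number fell.

Going by these compounds, it remains open whether only a methoxy group gives this gain, or whether a hydroxyl group or an amine in the same place would do the same. On these data alone, a longer chain on that oxygen is equally open.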